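Hydroxyphenyl-substituted series: cytotoxicity in HEK293 cells

The source may hold more compounds than are shown below. What is called first, only, known or untested is meant among the compounds shown, and "the series" means these compounds.

Measured compounds:
- compound 1, `Oc1ccc(-c2cc(-c3ccccc3O)cc(-c3cccc(O)c3)n2)cc1`, 5650 nM
- compound 2, `Oc1cccc(-c2cc(-c3ccccc3O)nc(-c3ccccc3O)c2)c1`, 80 nM
- compound 3, `Oc1cccc(-c2cc(-c3cccc(O)c3)nc(-c3ccccc3O)c2)c1`, > 50000 nM

Compound 3 stands at the bottom of the range in an ADME assay on HEK293 cells (Homo sapiens) for cytotoxicity, read by CCK-8 assay, with a stated time of 4 days; on this read-out higher numbers stand for weaker inhibition and lower numbers for stronger inhibition; its value is a limit of this assay and not a number, and the limit of > 50000 nM in this assay, at which 1 of the 3 values shown sits, marks that one of the values shown sits there. Within the measured set the only step relevant to compound 3 is an at least 620-fold higher number from compound 2 to compound 3 (2.79 log units; beyond the scatter), a large loss of inhibition when a 2-hydroxyphenyl gives way to a 3-hydroxyphenyl on the shared core. Compound 1, which carries a 4-hydroxyphenyl beside one 2-hydroxyphenyl and one 3-hydroxyphenyl, gives 5650 nM; compound 2, with two 2-hydroxyphenyl groups, gives 80 nM.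

Compound 4, `Oc1ccc(-c2cc(-c3cccc(O)c3)cc(-c3cccc(O)c3)n2)cc1`, is not yet measured. It differs from compound 3 by 4-hydroxyphenyl in place of 2-hydroxyphenyl on an aromatic carbon, so the last 2-hydroxyphenyl of the shared core is removed. Among the measured compounds shown here, both compounds with a 2-hydroxyphenyl count of one or two give numbers, while compound 3 already sits at the limit; no measured pair isolates the 2-hydroxyphenyl to 4-hydroxyphenyl swap. The expectation is therefore no gain, and most likely another limit. Compound 4 is expected to give 80000 nM (range 20000 nM to 300000 nM), an estimated step that the limit leaves unreadable from compound 3 to compound 4.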

Compound 4, half-maximal inhibitory concentration: 1560 nM
The estimate for compound 4 lay 51-fold (1.71 log units) above the measured number, and the stated range ends above it.
By their numbers in this assay, from the lowest: compound 2; then compound 4; then compound 1. At a limit, above all of these: compound 3.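

At the place next to the ring nitrogen, 4-hydroxyphenyl in place of 2-hydroxyphenyl gives an at least 32-fold lower number from compound 3 to compound 4 (1.50 log units; beyond the scatter) in this assay and so a 2-hydroxyphenyl at this place is not needed for a reading inside the range of the assay. Compound 3 gives > 50000 nM as a limit and not a number. The swap of 2-hydroxyphenyl for 3-hydroxyphenyl also loses its single direction, since it now gives a 3.6-fold lower number from compound 1 to compound 4 (0.56 log units; beyond the scatter) and the outcome of this change depends on the core that carries it: the same change on two cores in this assay, an at least 620-fold higher number (2.79 log units; beyond the scatter) from compound 2 to compound 3 and a 3.6-fold lower number (0.56 log units; beyond the scatter) from compound 1 to compound 4, at least 2200-fold (3.35 log units) apart, beyond the scatter of two such steps.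

All the groups shown on the shared core are hydroxyphenyl groups, so it remains open whether a methoxyphenyl or an unsubstituted phenyl at the place next to the ring nitrogen would read like the 4-hydroxyphenyl or like the 2-hydroxyphenyl. From the compounds shown here alone, it also remains open how far the 2-hydroxyphenyl to 4-hydroxyphenyl swap would move the number on a core where both compounds of the pair read inside the range, and whether it would move in the same direction.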